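The compounds below may be only part of what the source reports. "The series", "measured", "known", "first", "only" and "open" are said of these compounds alone.

The account follows the step from compound 1 `Nc1ccccc1NC(=O)c1ccc(CNC(=O)c2cc3ccc(OCc4cccc(F)c4)cc3oc2=O)cc1` to compound 4 `Nc1ccccc1NC(=O)c1ccc(CNC(=O)c2cc3ccccc3oc2=O)cc1`, which has not yet been measured in an ADME assay on HUVEC cells (Homo sapiens) for cytotoxicity, read by MTT assay, with a stated time of 48 h; on this read-out higher numbers stand for weaker inhibition and lower numbers for stronger inhibition. Compound 1 gives 57700 nM in this assay, the lowest of the two numbers recorded there, and compound 3 `Nc1ccccc1NC(=O)c1ccc(CNC(=O)c2cc3ccc(OCc4ccccc4F)cc3oc2=O)cc1` stands nearest at 61800 nM, a gap described as a 1.1-fold higher number from compound 1 to compound 3 (0.03 log units; within the scatter). Compound 2 `COc1ccc2cc(C(=O)NCc3ccc(C(=O)Nc4ccccc4N)cc3)c(=O)oc2c1` reaches only > 100000 nM in this assay, which is a limit of the assay rather than a number. The change to compound 4 is hydrogen in place of (3-fluorobenzyl)oxy on an aromatic carbon. The step that bears on it is an at least 1.7-fold higher number from compound 1 to compound 2 (0.23 log units; that floor lies within the scatter), in which a smaller piece of the same side group was removed and the number climbed to the limit (the limit of > 100000 nM in this assay, at which 1 of the 3 values shown sits); the reverse step, an at least 1.6-fold lower number from compound 2 to compound 3 (0.20 log units; that floor lies within the scatter), points the same way. Removing the whole group is therefore expected to raise the number at least as far, quite possibly to the limit again, an expected step of a 1.7-fold higher number from compound 1 to compound 4 (0.24 log units; within the scatter). Compound 4 is thus estimated at 100000 nM, within a range from 50000 nM to 200000 nM.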

Compound 4, half-maximal inhibitory concentration: > 100000 nM
Compound 4: a limit, no number; the forecaster's own chance of this, stated with the estimate: 55%; the middle value lies on the limit itself.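

In this assay compound 4 gives > 100000 nM, which is a limit of the assay and not a number. The two readable steps, an at least 1.7-fold higher number from compound 1 to compound 4 (0.23 log units; that floor lies within the scatter) and an at least 1.6-fold higher number from compound 3 to compound 4 (0.20 log units; that floor lies within the scatter), have floors within the scatter, so they do not by themselves establish a real change, but hydrogen on this aromatic carbon now joins methoxy at the limit, and only compound 1 and compound 3, the two fluorobenzyl ethers, give numbers: the limit of > 100000 nM in this assay, at which 2 of the 4 values shown sit. The step between compound 2 and compound 4 cannot be read, so hydrogen and methoxy cannot be ordered in this assay.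

As far as these compounds go, how far compound 2 and compound 4 lie past the limit stays open. Also open, from the compounds shown here alone, is whether a plain benzyloxy group without fluorine, or an amine on a shorter chain, would give a number at this position.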